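The source may hold more compounds than are shown below. What is called first, only, known or untested is meant among the compounds shown, and "the series" means these compounds.

Measured in a functional assay on HeLa cells (Homo sapiens) for inhibition, read by CCK-8 assay, with a stated time of 48 h; on this read-out lower numbers stand for stronger inhibition and higher numbers for weaker inhibition:
- Compound 1 `O=C(NCCNS(=O)(=O)c1ccc(-c2ccccc2OCc2cccc(O)c2)s1)Nc1cc(C(F)(F)F)cc(C(F)(F)F)c1`: 17300 nM
- Compound 2 `O=C(NCCNS(=O)(=O)c1ccc(-c2ccccc2Oc2ccc([N+](=O)[O-])c([N+](=O)[O-])c2)s1)Nc1cc(C(F)(F)F)cc(C(F)(F)F)c1`: > 50000 nM

Compound 2 stands at > 50000 nM, which is a limit of the assay and not a number.

Compound 3 `O=C(NCCNS(=O)(=O)c1ccc(-c2ccccc2OCc2ccccc2)s1)Nc1cc(C(F)(F)F)cc(C(F)(F)F)c1` differs from it in one group: benzyl in place of 3,4-dinitrophenyl on an oxygen on an aromatic ring. Among the compounds with values here, the one measured step at this place is an at least 2.8-fold higher number from compound 1 to compound 2 (0.46 log units; beyond the scatter), where 3,4-dinitrophenyl replaced 3-hydroxybenzyl. With benzyl in that place, compound 3 looks more like compound 1 at 17300 nM, so a step of similar size in the opposite direction is expected. The expected change is an at least 2.5-fold lower number from compound 2 to compound 3 (0.39 log units; beyond the scatter). The estimate for compound 3 is 20000 nM, with an expected range from 7000 nM to 50000 nM.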

Compound 3, half-maximal inhibitory concentration: 13500 nM
Compound 3: middle estimate off by 1.5-fold (0.17 log units), on the high side; the range from low to high includes it.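

Swapping 3,4-dinitrophenyl for benzyl on this oxygen gives an at least 3.7-fold lower number from compound 2 to compound 3 (0.56 log units; beyond the scatter), so this position can keep activity without the hydroxy group of compound 1. Within the data shown here, compound 2 is the one compound that sits at a limit of the assay: the limit of > 50000 nM in this assay, at which 1 of the 3 values shown sits. Taking away the hydroxy gives a 1.3-fold lower number from compound 1 to compound 3 (0.11 log units; within the scatter), so the hydroxy makes no readable difference here.

Still open, as far as these compounds go, is whether the gap follows the two nitro groups or the benzyl link, which plain phenyl on this oxygen could separate. From the compounds shown here alone, an amine or carboxylic acid on the benzyl ring also remains untested ground.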